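Adding a Hydroxymethyl Group to the Weakest Compound

A few compounds are considered here, and "the series" means these few. Any claim that something is new, unique, unknown or untested is made for them only; others in the source may bear on it.

Compound 1 `O/N=C(/Nc1cccc(F)c1)c1ccc2occc2c1` is the weaker of two measured compounds: in an assay on tissue (HeLa cells) for inhibition of Indoleamine 2,3-dioxygenase 1 (Homo sapiens), read by spectrophotometry (on this read-out higher numbers stand for weaker inhibition and lower numbers for stronger inhibition), compound 1 gives 20000 nM, the highest number of the pair. Its partner, compound 2 `O/N=C(/Nc1cccc(Cl)c1)c1ccc2occc2c1`, differs in one place, chloro in place of fluoro on an aromatic carbon, and in this assay compound 2 gives 1500 nM; that is a 13-fold lower number from compound 1 to compound 2 (1.12 log units; beyond the scatter).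

Compound 3 `OCc1cc2cc(/C(=N\O)Nc3cccc(F)c3)ccc2o1` has not yet been measured. It departs from compound 1 by hydroxymethyl in place of hydrogen on an aromatic carbon, a group added to the shared core rather than an exchange of the halogen. Going by the values given here, the one measured step concerns that halogen exchange alone and so says nothing about what a hydroxymethyl on the core does. Among the compounds with values here, with no step bearing on this change, no movement beyond the scatter can be predicted, and the starting point of compound 1 is kept, with a wide margin of doubt. Compound 3 is therefore expected to show a 1.3-fold lower number from compound 1 to compound 3 (0.12 log units; within the scatter), an estimate of 15000 nM in this assay, with the plausible span expected to run from 3000 nM to 60000 nM.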

Compound 3, half-maximal inhibitory concentration: 2400 nM
Compound 3: middle estimate off by 6.3-fold (0.80 log units), on the high side; the whole stated range lies above it.
By their numbers in this assay, from the lowest: compounds 2 and 3 (each within the scatter of the next); then compound 1.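

Putting a hydroxymethyl on an aromatic carbon of the five-membered aromatic ring, next to the ring oxygen, produces in this assay an 8.3-fold lower number from compound 1 to compound 3 (0.92 log units; beyond the scatter), so this position on the shared core is one where an added group can move the number beyond the scatter. The earlier pair showed only what an exchange of halogen does, whereas this step shows that the core itself can also be changed with a clear effect on the read-out, with the fluoro group left in place. Nothing measured here accounts for the lower number, so the step stands as an observation without an explanation.

On these data alone, it remains open whether the lower number belongs to the hydroxymethyl specifically or whether other groups at this position, such as a plain methyl, a longer chain ending in a hydroxyl, an amine or a carboxylic acid, would move it in the same way. Going by these compounds alone, the addition is also seen only on the fluoro compound, so its size on the chloro compound, compound 2, remains unknown.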